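This account rests on a few compounds, and the source may have more. Where it says the series, first, only, none or still open, it means among the compounds named here.

Measured in a functional assay on HCT-8 cells (Homo sapiens) for cytotoxicity; on this read-out higher numbers stand for an effect only at larger amounts of compound and lower numbers for an effect already at smaller amounts:
Compound 1 `COC1=C(C)C(=O)/C(=C(O)/C=C/c2ccc(OC)cc2)C(=O)C1(C)C`: 5.6 ug/mL
Compound 2 `COC1=C(C)C(=O)/C(=C(O)/C=C/c2cccc(OC)c2)C(=O)C1(C)C`: 2.9 ug/mL
Compound 3 `COC1=C(C)C(=O)/C(=C(O)/C=C/c2ccc(C)cc2)C(=O)C1(C)C`: 4.1 ug/mL

Compound 3, at 4.1 ug/mL, lies within the scatter of both other compounds. Compound 4 `COC1=C(C)C(=O)/C(=C(O)/C=C/c2ccccc2C)C(=O)C1(C)C` differs from it by 2-methylphenyl in place of 4-methylphenyl on a double-bonded chain carbon bound to a double-bonded chain carbon; the two have the same atoms, joined differently. Among the measured compounds shown here, the closest precedent is a 1.9-fold lower number from compound 1 to compound 2 (0.29 log units; within the scatter), where the methoxy group changes place on the phenyl ring, and this stays within the scatter. The other two steps, a 1.4-fold lower number from compound 1 to compound 3 (0.14 log units; within the scatter) and a 1.4-fold higher number from compound 2 to compound 3 (0.15 log units; within the scatter), are also within the scatter. In this assay no step beyond the scatter is therefore expected, and the estimated step is a 1.0-fold lower number from compound 3 to compound 4 (0.01 log units; within the scatter). For compound 4 the estimated value is 4 ug/mL, with an expected range from 2 ug/mL to 8 ug/mL.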

Compound 4, concentration for half-maximal effect: 4 ug/mL
For compound 4 middle estimate and measured number coincide at the digits printed; low and high end bracket the measured number.
By their numbers in this assay, from the lowest: compounds 2, 4, 3 and 1 (each within the scatter of the next).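

In this assay the shift of the methyl group to 2-methylphenyl gives a 1.0-fold lower number from compound 3 to compound 4 (0.01 log units; within the scatter) and so, like the methoxy shift before it, produces no step beyond the scatter at this place. Compound 4 also lies within the scatter of both methoxy compounds, with a 1.4-fold higher number from compound 2 to compound 4 (0.14 log units; within the scatter) and with a 1.4-fold lower number from compound 1 to compound 4 (0.15 log units; within the scatter) as well. Nothing available offers an explanation for these results. The compounds shown leave open whether an amine or a carboxylic acid on the phenyl ring would give a step beyond the scatter. The same question stands for a longer chain in place of the methyl group.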